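The source may report more compounds than this note shows. Statements on the series, on what has been measured and on what is new or still open speak of the compounds shown alone.

Working notes on the methoxy-phenyl series

Compound 1 `COc1ccccc1-c1nc2cc(F)ccc2o1` is the anchor. In a functional assay on MCF7 cells (Homo sapiens) for inhibition (on this read-out higher numbers stand for weaker inhibition and lower numbers for stronger inhibition), compound 1 gives 360 nM. Compound 2 `COc1cccc(OC)c1-c1nc2cc(F)ccc2o1` carries one more methoxy group and in this assay gives 58100 nM; the change is methoxy in place of hydrogen on an aromatic carbon, and the step is a 160-fold higher number from compound 1 to compound 2 (2.21 log units; beyond the scatter). Compound 3 `COc1ccc(-c2nc3ccc(F)cc3o2)cc1` has the same atoms as compound 1 joined differently; the difference between the two cores is not broken down here. In this assay compound 3 gives 41000 nM, which lies within the scatter of the number for compound 2.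

Compound 4 `COc1ccc(-c2nc3ccc(F)cc3o2)c(OC)c1` is not yet measured. It differs from compound 3 by methoxy in place of hydrogen on an aromatic carbon, the same change as from compound 1 to compound 2; the surroundings of the place read the same in both cases. Two things pull apart. Taken literally, the earlier step would carry compound 4 far past the number of compound 3. Yet compound 4 also contains the methoxy group that compound 1 carries alone, and compound 1 is the only member with a low number here, so the step from compound 3 to compound 4 is estimated at a 2.7-fold lower number from compound 3 to compound 4 (0.44 log units; beyond the scatter), smaller than the earlier one and uncertain in sign, because compound 1 gives 360 nM while compound 3 gives 41000 nM. Compound 4 is therefore expected in this assay near 15000 nM, with a wide band from 1500 nM to 150000 nM; a result reported only as a limit cannot be ruled out.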

Compound 4, half-maximal inhibitory concentration: 69900 nM
Compound 4: the middle estimate sits 4.7-fold (0.67 log units) below what was measured; low and high end bracket the measured number.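

In this assay the new step reads a 1.7-fold higher number from compound 3 to compound 4 (0.23 log units; within the scatter), while the same change on the other core reads a 160-fold higher number from compound 1 to compound 2 (2.21 log units; beyond the scatter). In this series, therefore, the size of the step from adding this methoxy group does not carry over from one core to the other: the same change on two cores in this assay, a 160-fold higher number (2.21 log units; beyond the scatter) from compound 1 to compound 2 and a 1.7-fold higher number (0.23 log units; within the scatter) from compound 3 to compound 4, 95-fold (1.98 log units) apart, beyond the scatter of two such steps

The comparison rests on a single pair per core, with compound 1 starting the large step at 360 nM and compound 3 starting the small one at 41000 nM. It shows that the step depends on the core in these two cases, but it does not show why the steps differ or how the change would read on any further core.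

The compounds shown carry only methoxy groups on the aromatic ring that bears them, so it remains open how a hydroxyl, an amine, a carboxylic acid or a longer chain such as ethoxy would read in the same place on either core. Every compound shown also carries one fluorine, which leaves open how the numbers would read with hydrogen, chlorine or a nitrile in its place.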